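Bromo for 4-methylpiperazin-1-yl: estimating a cell toxicity value

The compounds below may be only part of what the source reports. "The series", "measured", "known", "first", "only" and "open" are said of these compounds alone.

Three compounds share one core, and the test here is an ADME assay on Vero cells (Chlorocebus sabaeus) for cytotoxicity, read by MTT assay, with a stated time of 72 h (on this read-out higher numbers stand for lower toxicity in this test and lower numbers for higher toxicity in this test), in which compound 1 `COc1cc(-c2cc(-c3ccc(C4NC(=O)c5ccccc5N4)cc3)nc(N)n2)cc(OC)c1OC` gives 85900 nM as its result. Compound 2 `Nc1nc(-c2ccc(F)cc2)cc(-c2ccc(C3NC(=O)c4ccccc4N3)cc2)n1` carries the entry "not determined" (no result reported) and so adds no number. Compound 3 `CN1CCN(c2ccc(-c3cc(-c4ccc(C5NC(=O)c6ccccc6N5)cc4)nc(N)n3)cc2)CC1` gives 8320 nM as its result, the lower of the two numbers available, and its gap to compound 1 lies beyond the usual scatter of repeated measurements.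

Compound 4 `Nc1nc(-c2ccc(Br)cc2)cc(-c2ccc(C3NC(=O)c4ccccc4N3)cc2)n1` has not yet been measured in this assay and differs from compound 3 in one place, with bromo in place of 4-methylpiperazin-1-yl on an aromatic carbon, para to a large group (counted: bromo in place of 4-methylpiperazin-1-yl on an aromatic carbon) and nothing else changed.

Among the compounds with values here, no measured pair differs in only one place, so there is no direct precedent for this change. With just two numbers to go on, the expectation is a move upward from compound 3 toward compound 1 at 85900 nM on this scale, which would mean lower toxicity in this test. The estimated change is a 4.2-fold higher number from compound 3 to compound 4 (0.62 log units; beyond the scatter) in that upward direction, beyond the scatter but uncertain. Compound 4 is expected at 35000 nM with an estimated range from 12000 nM to 100000 nM on present evidence.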

Compound 4, half-maximal cytotoxic concentration: > 400000 nM
Compound 4: a limit, no number (the forecaster's own chance of this, stated with the estimate: 20%); at least 11-fold (1.05 log units) between middle value and limit.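

The result for compound 4 in this assay is a limit of the assay and not a number: the limit of > 400000 nM in this assay, at which 1 of the 4 values shown sits.

Within the data shown here, until now no two measured compounds differed in one place, so nothing showed how much this aromatic carbon, para to a large group, matters for the read-out. Bromo in place of 4-methylpiperazin-1-yl now gives an at least 48-fold higher number from compound 3 to compound 4 (1.68 log units; beyond the scatter), which is a large move toward lower toxicity in this test. Placing 4-bromophenyl instead of 3,4,5-trimethoxyphenyl on the shared core gives an at least 4.6-fold higher number from compound 1 to compound 4 (0.66 log units; beyond the scatter), so the bromo compound also stands clear of the trimethoxy compound, and both steps are minimum sizes whose true extent the limit hides.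

The compounds shown cannot separate what bromo brings from what is lost with 4-methylpiperazin-1-yl, and a chloro group, a plain hydrogen or a small open-chain amine such as dimethylamino at this carbon would help to tell these apart. From the compounds shown here alone, they also give no reason for the change, and whether the same step would hold on a different core remains open.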